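Thiadiazolylsulfanyl for Hydroxy on Two Sugar Cores

A few compounds are considered here, and "the series" means these few. Any claim that something is new, unique, unknown or untested is made for them only; others in the source may bear on it.

Compound 1 `O=[N+]([O-])c1ccc(-c2nc(CO[C@@H]3O[C@H](CO)[C@H]4OC5(CCCC5)O[C@@H]34)no2)cc1` carries a hydroxy group on a saturated chain carbon bound to a saturated ring carbon. In a functional assay on A549 cells (Homo sapiens) for antiproliferative activity, read by sulforhodamine B assay, with a stated time of 48 h (a higher number here means a weaker inhibitor of growth, a lower number a stronger inhibitor of growth), compound 1 gives 32000 nM. Compound 2 `Nc1nnc(SC[C@H]2O[C@@H](OCc3noc(-c4ccc([N+](=O)[O-])cc4)n3)[C@@H]3OC4(CCCC4)O[C@@H]32)s1` differs from it only by (5-amino-1,3,4-thiadiazol-2-yl)sulfanyl in place of hydroxy on a saturated chain carbon bound to a saturated ring carbon, and in this assay compound 2 gives 14000 nM. That one change produced a 2.3-fold lower number from compound 1 to compound 2 (0.36 log units; beyond the scatter).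

Compound 3 `CC1(C)O[C@H]2[C@H](OCc3noc(-c4ccc([N+](=O)[O-])cc4)n3)O[C@H](CO)[C@H]2O1` has a different core; the difference between the cores of compound 3 and compound 1 is not broken down here. In this assay compound 3 gives 99000 nM, the highest of the three numbers. Compound 4 `CC1(C)O[C@H]2[C@H](OCc3noc(-c4ccc([N+](=O)[O-])cc4)n3)O[C@H](CSc3nnc(N)s3)[C@H]2O1` is derived from compound 3 by (5-amino-1,3,4-thiadiazol-2-yl)sulfanyl in place of hydroxy on a saturated chain carbon bound to a saturated ring carbon, the same change as that from compound 1 to compound 2, at the same place.

Because the earlier change gave a 2.3-fold lower number from compound 1 to compound 2 (0.36 log units; beyond the scatter), compound 4 is expected to show a step of similar size, estimated as a 2.3-fold lower number from compound 3 to compound 4 (0.36 log units; beyond the scatter). On that basis compound 4 is expected to give about 43000 nM in this assay, between 20000 nM and 90000 nM, with compound 3 as the only anchor for this core.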

Compound 4, concentration for 50% growth inhibition: > 100000 nM
Compound 4 gave a limit, no number; the forecaster's own chance of this, stated with the estimate: 10%; middle value at least 2.3-fold (0.36 log units) away from the limit.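

In this assay compound 4 gives > 100000 nM, which is a limit of the assay and not a number, so the size of the step from compound 3 cannot be read. Set beside each other, the two occurrences of the change compare as follows: the same change on two cores in this assay, a 2.3-fold lower number (0.36 log units; beyond the scatter) from compound 1 to compound 2 and a number no lower (the limit leaves the size open) from compound 3 to compound 4; the limit leaves it open whether they differ The result is a number no lower from compound 3 to compound 4 (the limit leaves the size open), so the lower number seen on the core of compound 1 was not seen on this second core, but it does not show how far apart the two compounds lie, nor that the change truly acts differently on the two cores.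

The compounds shown leave open how other groups, such as an amine or a carboxylic acid, would behave in place of hydroxy on a saturated chain carbon bound to a saturated ring carbon on either core. They also leave open what part the amino group of the (5-amino-1,3,4-thiadiazol-2-yl)sulfanyl group plays, as every thiadiazole shown carries it.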